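Replacing the amide aryl group with an arylamino on the shared core

The compounds below may be only part of what the source reports. "The series", "measured", "known", "first", "only" and "open" are said of these compounds alone.

compound 1 `COc1cc(-c2nn(-c3cccc(NC(=O)c4cccc(C(F)(F)F)c4)c3)cc2-c2ccncc2)ccc1Cl` gives 1670 nM
compound 2 `O=C(Nc1cccc(-n2cc(-c3ccncc3)c(-c3ccc(Cl)c(O)c3)n2)c1)Nc1cc(C(F)(F)F)cc(C(F)(F)F)c1` gives 428 nM

In a functional assay on HCT-116 cells (Homo sapiens) for inhibition, read by sulforhodamine B assay, with a stated time of 48 h (a higher number here means a weaker inhibitor of growth, a lower number a stronger inhibitor of growth), compound 1 gives 1670 nM, the highest of the two numbers. Compound 2 gives 428 nM, a lower number beyond the scatter, though compound 2 differs from compound 1 in more than one place. Compound 3 `COc1cc(-c2nn(-c3cccc(NC(=O)Nc4ccc(Cl)c(C(F)(F)F)c4)c3)cc2-c2ccncc2)ccc1Cl` has not been measured. It differs from compound 1 in one place: (4-chloro-3-(trifluoromethyl)phenyl)amino in place of 3-(trifluoromethyl)phenyl on a carbonyl carbon. The step from compound 1 to compound 3 in this assay is expected to be a moderate move toward a lower number, a 2.8-fold lower number from compound 1 to compound 3 (0.44 log units; beyond the scatter). Compound 3 is estimated at 600 nM, within a range from 180 nM to 2000 nM.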

Compound 3, concentration for 50% growth inhibition: 1170 nM
For compound 3 the middle estimate is 2.0-fold (0.29 log units) below the measured one; low and high end bracket the measured number.
By their numbers in this assay, from the lowest: compound 2; then compounds 3 and 1 (each within the scatter of the next).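

In this assay, among these compounds, (4-chloro-3-(trifluoromethyl)phenyl)amino in place of 3-(trifluoromethyl)phenyl on a carbonyl carbon gives a 1.4-fold lower number from compound 1 to compound 3 (0.15 log units; within the scatter), the first change here that can be read on its own. The entering group brings a hydrogen-bond donor and a chlorine, yet at this place the two compounds are not separated. Nothing available bears on why this exchange leaves them within the scatter.

The compounds shown leave open whether the amino link and the chlorine would each give the same reading alone. They also leave open how a nitrile or a carboxylic acid in place of that chlorine would read.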